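Chain extension on the aryl ether of compound 1

The source may hold more compounds than are shown below. What is called first, only, known or untested is meant among the compounds shown, and "the series" means these compounds.

Compound 1 `CCOc1ccc([C@@H]2CC(=O)c3cc(CC=C(C)C)c(OC)cc3O2)cc1` carries the ethoxy group of this set. In a functional assay on MCF7 cells (Homo sapiens) for inhibition, read by sulforhodamine B assay, with a stated time of 48 h, tested at 50 uM (on this read-out higher numbers stand for more inhibition of growth at the one concentration tested and lower numbers for less inhibition of growth), compound 1 gives 57%, the second highest of three numbers. Compound 3 `COc1ccc([C@@H]2C/C(=N/O)c3cc(CC=C(C)C)c(OC)cc3O2)cc1` gives 63%, a value within the scatter of compound 1. Compound 2 `COc1ccc([C@@H]2C/C(=N/OCc3cn(-c4ccc(C(=O)c5ccccc5)cc4)nn3)c3cc(CC=C(C)C)c(OC)cc3O2)cc1` gives 41%, a number below compound 1 by more than the scatter. Compound 4 `CCCCOc1ccc([C@@H]2CC(=O)c3cc(CC=C(C)C)c(OC)cc3O2)cc1` keeps the shared core and differs from compound 1 by ethyl in place of hydrogen on a saturated chain carbon, two bonds along the chain from an oxygen on an aromatic ring. Within the data shown here, no measured pair shows this kind of change, so the size of the step cannot be read from the set. In this assay the expected step is a number 2 percentage points lower from compound 1 to compound 4 (within the scatter), nothing beyond the scatter in either direction. Compound 4 is therefore estimated at 55%, with a range from 35% to 75%.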

Compound 4, percent growth inhibition at one concentration: 57%
Estimate against measurement, compound 4: 2 percentage points below; low and high end bracket the measured number.
By their numbers in this assay, from the lowest: compound 2; then compounds 1, 4 and 3 (each within the scatter of the next).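

In this assay, among these compounds, the step of no change at the digits printed from compound 1 to compound 4 (within the scatter) is the first reading of any change at this position: ethoxy to butoxy, with ethyl in place of hydrogen on a saturated chain carbon, two bonds along the chain from an oxygen on an aromatic ring. At the one concentration tested, the added ethyl leaves growth inhibition where it was. No measurement on hand accounts for this outcome.

As far as these compounds go, whether a longer chain such as hexyloxy would hold the same level remains open, as does the effect of a terminal amine or carboxylic acid on this chain. From the compounds shown here alone, whether compound 1 and compound 4 also match at other concentrations is equally open.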